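A few compounds are considered here, and "the series" means these few. Any claim that something is new, unique, unknown or untested is made for them only; others in the source may bear on it.

Measured so far in a functional assay on L1210 cells (Mus musculus) for antiproliferative activity; a higher number here means that more compound is needed for the effect, a lower number that less compound is needed:
- compound 1, `CCCCCC/C(=N\OCCCCC)c1cc(OC)c2c(c1OC)C(=O)C=CC2=O`: 0.224 ug/mL
- compound 2, `CCCCCCCCCO/N=C/c1cc(OC)c2c(c1OC)C(=O)C=CC2=O`: 0.19 ug/mL

Of the two numbers, compound 1 carries the larger, yet the gap to compound 2 stays within the usual scatter, so the two compounds look alike in this assay. Compound 3, `CCCCCCCCCO/N=C(\CCCCCC)c1cc(OC)c2c(c1OC)C(=O)C=CC2=O`, keeps the core of compound 1 and differs from it by one change: butyl in place of hydrogen on a saturated chain carbon, five bonds along the chain from an oxygen on an unsaturated carbon. Compound 2 already carries a nonyl chain on the oxygen and, in this assay, compound 2 gives 0.19 ug/mL, close to the value of compound 1. Among the measured compounds shown here, no measured pair isolates this exact change, so the expectation rests on how little the two measured values differ. On that basis the step of a 1.0-fold lower number from compound 1 to compound 3 (0.01 log units; within the scatter) is expected to be none beyond the scatter. Compound 3 is therefore expected to give about 0.22 ug/mL, with a likely range from 0.08 ug/mL to 0.6 ug/mL.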

Compound 3, concentration for half-maximal effect: 1.15 ug/mL
Estimate against measurement, compound 3: 5.2-fold (0.72 log units) below, and the stated range ends below it.
By their numbers in this assay, from the lowest: compounds 2 and 1 (each within the scatter of the next); then compound 3.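

In this assay, putting butyl in place of hydrogen on a saturated chain carbon, five bonds along the chain from an oxygen on an unsaturated carbon, gives a 5.1-fold higher number from compound 1 to compound 3 (0.71 log units; beyond the scatter), so more compound is needed for the same effect. The earlier values could not show this: they gave no direct view of this change, whereas this pair shows that the added butyl is not neutral at this position and that the step lies beyond the usual scatter. No measurement available here explains the shift.

A single step cannot show whether the number rises gradually as the chain grows or jumps at one particular length. On these data alone, how ethyl, a longer chain such as octyl, or an amine in place of butyl would behave at this position remains open.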